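The source may report more compounds than this note shows. Statements on the series, on what has been measured and on what is new or still open speak of the compounds shown alone.

In an ADME assay on MT4 cells (Homo sapiens) for cytotoxicity (on this read-out higher numbers stand for lower toxicity in this test and lower numbers for higher toxicity in this test), three compounds have been measured:

compound 1, `Cc1cc(C)cc(Cn2c(SCC(=O)Nc3ccc(S(C)(=O)=O)cc3Cl)nc3ccccc32)c1`, gives 106000 nM
compound 2, `Cc1cc(C)cc(Cn2c(SCC(=O)Nc3ccc(S(C)(=O)=O)cc3Cl)nc3ccc(Cl)cc32)c1`, gives 88800 nM
compound 3, `Cc1cc(C)cc(Cn2c(SCC(=O)Nc3ccc(S(N)(=O)=O)cc3Cl)nc3ccccc32)c1`, gives 111000 nM

Compound 4, `Cc1cc(C)cc(Cn2c(SCC(=O)Nc3ccc(S(N)(=O)=O)cc3Cl)nc3ccc(Cl)cc32)c1`, has not yet been measured in this assay. It differs from compound 3 by one change, (chloro in place of hydrogen on an aromatic carbon). The same change has already been made once, from compound 1 to compound 2, where it is chloro in place of hydrogen on an aromatic carbon; that step came out as a 1.2-fold lower number from compound 1 to compound 2 (0.08 log units; within the scatter). The place of the change is described in the same words for both pairs, so it is the same change on two different cores. The two cores themselves differ in one spot, (amino in place of methyl on a sulfonyl sulfur), and that difference gave a 1.0-fold higher number from compound 1 to compound 3 (0.02 log units; within the scatter), so the two starting points stand close together in this assay. Among the measured compounds shown here, with only one earlier example, the expectation for compound 4 rests on that single step: the move from compound 3 to compound 4 is estimated as a 1.2-fold lower number from compound 3 to compound 4 (0.08 log units; within the scatter) because of a 1.2-fold lower number from compound 1 to compound 2 (0.08 log units; within the scatter). Compound 4 is therefore expected to give about 93000 nM in this assay, most likely between 50000 nM and 180000 nM.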

Compound 4, half-maximal cytotoxic concentration: >= 18500 nM
Compound 4 gave a limit, no number; the forecaster's own chance of this, stated with the estimate: 10%; the middle value lies beyond the limit too.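

In this assay compound 4 gives >= 18500 nM, which is a limit and not a number. The steps from compound 2 and from compound 3 to compound 4 therefore cannot be read. The compounds shown leave open whether chloro in place of hydrogen on an aromatic carbon shifts the number on the core of compound 3.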